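Cyanoaziridine ureas: nitro in place of ethoxycarbonyl

The compounds below may be only part of what the source reports. "The series", "measured", "known", "first", "only" and "open" are said of these compounds alone.

Compound 1 `CCOC(=O)c1ccc(NC(=O)N2CC2C#N)cc1` is measured in a functional assay on OVCAR-3 cells (Homo sapiens) for inhibition (on this read-out lower numbers stand for stronger inhibition and higher numbers for weaker inhibition), and gives 7700 nM. Compound 2 `N#CC1CN1C(=O)Nc1cccnc1` gives 10000 nM in this assay; the two numbers lie within the scatter of each other, so no order between them can be claimed. Compound 3 `N#CC1CN1C(=O)Nc1ccc([N+](=O)[O-])cc1` has not been measured; it differs from compound 1 by nitro in place of ethoxycarbonyl on an aromatic carbon. Among the measured compounds shown here, no measured step covers this change, so the expected step from compound 1 to compound 3 in this assay is small, a 1.2-fold lower number from compound 1 to compound 3 (0.07 log units; within the scatter), and not beyond the scatter. Compound 3 is therefore estimated at 6500 nM, within a range of 2000 nM to 20000 nM.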

Compound 3, half-maximal inhibitory concentration: 6500 nM
Estimate against measurement, compound 3: no gap at the digits printed; measured number inside the range.
By their numbers in this assay, from the lowest: compounds 3, 1 and 2 (each within the scatter of the next).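

In this assay, among the compounds shown here, nitro in place of ethoxycarbonyl on this aromatic carbon, para to a group of 8 heavy atoms, gives a 1.2-fold lower number from compound 1 to compound 3 (0.07 log units; within the scatter) as the first measured step at this position. A group of 3 heavy atoms thus stands in for one of 5 heavy atoms with no change beyond the scatter. No measured evidence bears on this result.

The compounds shown leave open whether an amine or a carboxylic acid on the same carbon would give a number beyond the scatter of compound 1. On these data alone, a longer chain there also remains open.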